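The source may hold more compounds than are shown below. What is called first, only, known or untested is meant among the compounds shown, and "the series" means these compounds.

Working notes on the series. Compound 1 `O=C(CCc1ccc(O)c(O)c1)N1CCN(S(=O)(=O)c2cccc3cnccc23)CC1` gives 320 nM in an assay on isolated protein for inhibition of Rho-associated protein kinase 2 (Homo sapiens), read by 33P incorporation, with a stated time of 30 min, in the presence of a further agent that is not named here; on this read-out lower numbers stand for stronger inhibition and higher numbers for weaker inhibition. Compound 2 `O=C(CCc1ccc(O)c(O)c1)N1CCCN(S(=O)(=O)c2cccc3cnccc23)CC1` gives 730 nM in this assay and so stands at the higher of the two numbers recorded, the gap to compound 1 lying beyond the usual scatter. Compound 3 `COc1cc(CCC(=O)N2CCCN(S(=O)(=O)c3cccc4cnccc34)CC2)ccc1O` differs from compound 2 by methyl in place of hydrogen on an oxygen on an aromatic ring. Among the measured compounds shown here, no measured pair in this set shows that change, so its direction rests on expectation alone; a modest weakening, or nothing beyond the scatter, is the expected outcome, the estimated step being a 1.4-fold higher number from compound 2 to compound 3 (0.14 log units; within the scatter). Compound 3 is therefore expected at 1000 nM in this assay, within 350 nM to 3000 nM.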

Compound 3, half-maximal inhibitory concentration: 900 nM
For compound 3 the middle estimate is 1.1-fold (0.05 log units) above the measured one; low and high end bracket the measured number.
By their numbers in this assay, from the lowest: compound 1; then compounds 2 and 3 (each within the scatter of the next).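

Methyl in place of hydrogen on an oxygen on an aromatic ring gives a 1.2-fold higher number from compound 2 to compound 3 (0.09 log units; within the scatter) in this assay, so hydroxy to methoxy at this position leaves the number within the scatter. The earlier compounds shown here both carried the 3,4-dihydroxyphenyl group and gave no reading of this position. Nothing measured here accounts for the result. Still open, going by these compounds, are ethyl or a longer chain on this oxygen and methyl on the remaining hydroxy. On these data alone, whether the step carries over to the core of compound 1 is also open.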